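A few compounds are considered here, and "the series" means these few. Any claim that something is new, unique, unknown or untested is made for them only; others in the source may bear on it.

In a functional assay on A-375 cells (Homo sapiens) for activation, with a stated time of 3 days (a higher number here means that more compound is needed for the effect, a lower number that less compound is needed), two compounds have been measured so far. Compound 1 `O=C(Nc1ccc(-c2cscn2)cc1)C1CCCN(Cc2cccc(C(F)(F)F)c2)C1` reaches only a limit of the assay, > 20000 nM. Among the compounds with values here, compound 2 `O=C(Nc1ccc(-c2cccnc2)cc1)C1CCCN(Cc2ccc(F)c(F)c2)C1` gives 1060 nM, the only actual number available. Compound 3 `O=C(Nc1ccc(-c2ncc[nH]2)cc1)C1CCCN(Cc2ccc(F)c(F)c2)C1` carries 1H-imidazol-2-yl in place of pyridin-3-yl, on an aromatic carbon of a six-membered aromatic ring of carbon only, para to a large group: 1H-imidazol-2-yl in place of pyridin-3-yl on an aromatic carbon. Within the data shown here, no measured step covers this swap. A modest rise in this assay is expected, with the estimated change being a 1.9-fold higher number from compound 2 to compound 3 (0.28 log units; within the scatter). For compound 3, the expected value is 2000 nM, with an estimated range of 400 nM to 10000 nM.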

Compound 3, half-maximal effective concentration: 8000 nM
Compound 3: the middle estimate sits 4.0-fold (0.60 log units) below what was measured; the measured number falls inside the stated range.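

At this position, on an aromatic carbon para to a large group, replacing pyridin-3-yl with 1H-imidazol-2-yl in this assay gives a 7.5-fold higher number from compound 2 to compound 3 (0.88 log units; beyond the scatter), so the assay responds to what sits here. The change does not take the series to the end of the scale, as compound 3 keeps a real number and only compound 1 stands at a limit: the limit of > 20000 nM in this assay, at which 1 of the 3 values shown sits.

The smaller ring and the added hydrogen-bond donor arrive together, and the compounds shown do not separate them. As far as these compounds go, how phenyl or an amine would read at this position also stays open.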